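From a Tetrazole to an Oxazole in Liver Microsomes

The compounds below may be only part of what the source reports. "The series", "measured", "known", "first", "only" and "open" are said of these compounds alone.

Compound 1, `CC(C)NC(=O)CC(c1ccc(-c2ccc3cccc(F)c3c2)[nH]c1=O)C(C)C`: in an ADME assay on microsomes from liver (Homo sapiens) for metabolic stability (on this read-out lower numbers stand for a shorter-lived compound and higher numbers for a longer-lived compound), compound 1 gives 0.32 h.
Compound 2, `CC(C)C(c1ccc(-c2ccc3cccc(F)c3c2)[nH]c1=O)N1CCCCC1=O`: compound 2 gives 0.183 h.
Compound 3, `CC(C)C(Cc1nnn[nH]1)c1ccc(-c2ccc3cccc(F)c3c2)[nH]c1=O`: compound 3 gives > 3 h, which is a limit of this assay and not a number.

Compound 3 thus stands at the upper edge of what the assay reports (the limit of > 3 h in this assay, at which 1 of the 3 values shown sits). Compound 4, `CC(C)C(c1ncco1)c1ccc(-c2ccc3cccc(F)c3c2)[nH]c1=O`, differs from compound 3 in one place: 1,3-oxazol-2-yl in place of (1H-tetrazol-5-yl)methyl on a saturated chain carbon bound to an aromatic carbon and a saturated chain carbon. The measured steps that bear on this are the two in which the tetrazole entered, an at least 9.3-fold higher number from compound 1 to compound 3 (0.97 log units; beyond the scatter) and an at least 16-fold higher number from compound 2 to compound 3 (1.21 log units; beyond the scatter), both beyond the scatter. Here the tetrazole leaves, so a drop beyond the scatter is expected, back toward the numbers of compound 1 and compound 2. The expected step is an at least 6.0-fold lower number from compound 3 to compound 4 (0.77 log units; beyond the scatter). Compound 4 is estimated at 0.5 h, within a range from 0.15 h to 2 h.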

Compound 4, half-life: 0.178 h
Estimate against measurement, compound 4: 2.8-fold (0.45 log units) above, and the stated range covers the measured number.
By their numbers in this assay, from the lowest: compounds 4, 2 and 1 (each within the scatter of the next). At a limit, above all of these: compound 3.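

The step of an at least 16-fold lower number from compound 3 to compound 4 (1.22 log units; beyond the scatter) shows that a five-membered aromatic ring on this saturated chain carbon does not by itself give the half-life of compound 3. Compound 4 instead stands with the compounds lacking a tetrazole, with a 1.0-fold lower number from compound 2 to compound 4 (0.01 log units; within the scatter) and a 1.8-fold lower number from compound 1 to compound 4 (0.25 log units; within the scatter), so among these four only (1H-tetrazol-5-yl)methyl stands apart. The value of compound 3 is a limit and not a number: the limit of > 3 h in this assay, at which 1 of the 4 values shown sits.

On these data alone, it remains open whether the half-life of compound 3 follows the tetrazole ring or the methyl part of (1H-tetrazol-5-yl)methyl. As far as these compounds go, it is also open whether a carboxylic acid on the same chain would stand with compound 3.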